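Expected clearance after one group swap in compound 4

The source may report more compounds than this note shows. Statements on the series, on what has been measured and on what is new or still open speak of the compounds shown alone.

Measured in an ADME assay on microsomes from liver (Homo sapiens) for metabolic stability, read by LC-MS, using NADPH, with stated times of 5 min and 30 min, tested at 1 uM (on this read-out higher numbers stand for fast clearance and lower numbers for slow clearance), the three compounds read as follows.

- Compound 1 `CN(C)Cc1ccc2c(c1)CN(c1cnc(NCc3c(F)ccc4c3CCO4)n3cnnc13)C2=O` gives 19 mL.min-1.g-1
- Compound 2 `Cc1ncc(-c2cnc(NCc3c(F)ccc4c3CCO4)c3cn[nH]c(=O)c23)n1C` gives 10 mL.min-1.g-1
- Compound 3 `CC1(C)CC(=O)N(c2cnc(NCc3c(F)ccc4c3CCO4)n3cnnc23)C1` gives 16 mL.min-1.g-1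

Compound 3, at 16 mL.min-1.g-1 in this set, lies within the usual scatter of both compound 1 and compound 2, so these numbers cannot be told apart. Compound 4 `O=C(Nc1cnc(NCc2c(F)ccc3c2CCO3)n2cnnc12)c1cccnc1` has not yet been measured. Compared with compound 3, it carries ((pyridin-3-yl)carbonyl)amino in place of 4,4-dimethyl-2-oxopyrrolidin-1-yl on an aromatic carbon and the rest of the structure stays the same. Within the data shown here, no two measured compounds differ in one place only, so the effect of this swap cannot be read directly from the data. Compound 1 at 19 mL.min-1.g-1 and compound 2 at 10 mL.min-1.g-1 carry other groups and still fall within the scatter of compound 3, which supports only a modest expectation. In this assay the expected change is small, with a 1.1-fold lower number from compound 3 to compound 4 (0.06 log units; within the scatter) as the estimate and nothing beyond the scatter expected. For compound 4 the estimated value is 14 mL.min-1.g-1 with an expected range from 6 mL.min-1.g-1 to 32 mL.min-1.g-1 in this measurement.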

Compound 4, intrinsic clearance in microsomes: < 3 mL.min-1.g-1
Compound 4 was reported as a limit; the forecaster's own chance of this, stated with the estimate: 3%; at least 4.6-fold (0.66 log units) between middle value and limit.
By their numbers in this assay, from the lowest: compounds 2, 3 and 1 (each within the scatter of the next). At a limit, below all of these: compound 4.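

In this assay, among these compounds, putting ((pyridin-3-yl)carbonyl)amino in place of 4,4-dimethyl-2-oxopyrrolidin-1-yl on this aromatic carbon gives an at least 5.3-fold lower number from compound 3 to compound 4 (0.72 log units; beyond the scatter), the only step here that changes a single place. The earlier compounds shown here differ in more than one place, so they could not tie any effect to this position; this step shows that the group on this carbon alone can move clearance beyond the scatter. The reading for compound 4 is a limit and not a number: the limit of < 3 mL.min-1.g-1 in this assay, at which 1 of the 4 values shown sits.

The entering group differs from the leaving one in several ways at once, including its aromatic ring and its amide hydrogen, so the compounds shown leave open which feature goes with the lower clearance. A phenyl in place of the pyridin-3-yl, or a methyl on the amide nitrogen, would help to separate these features.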